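From an acyclic amide to a ring-bound one

The source may report more compounds than this note shows. Statements on the series, on what has been measured and on what is new or still open speak of the compounds shown alone.

Compound 1: `CCOC(=O)C1CCN(C(=O)CN2CN(c3ccccc3)C3(CCN(C(=O)c4ccc(C(C)(C)C)cc4)CC3)C2=O)CC1`, 3100 nM
Compound 2: `CC(C)(C)c1ccc(C(=O)N2CCC3(CC2)C(=O)N(CC(=O)NCCCCO)CN3c2ccccc2)cc1`, 19200 nM
Compound 3: `COC(=O)CCCNC(=O)CN1CN(c2ccccc2)C2(CCN(C(=O)c3ccc(C(C)(C)C)cc3)CC2)C1=O`, "not determined" (no result reported)

Three compounds share a core in which the side-chain amide is varied. In an assay on HEK293 cells for displacement of a labelled ligand from NPC1-like intracellular cholesterol transporter 1 (Homo sapiens) (on this read-out lower numbers stand for stronger inhibition and higher numbers for weaker inhibition), compound 1 gives 3100 nM, and compound 2 gives 19200 nM. For compound 3 the result in this assay reads "not determined" (no result reported), so it stands without a value of its own. The change that leads from compound 3 to compound 4 (`CC(C)(C)c1ccc(C(=O)N2CCC3(CC2)C(=O)N(CC(=O)N2CCCC(CO)C2)CN3c2ccccc2)cc1`) is this: 3-(hydroxymethyl)piperidin-1-yl in place of (3-(methoxycarbonyl)propyl)amino on a carbonyl carbon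

Within the data shown here, the only measured step, a 6.2-fold higher number from compound 1 to compound 2 (0.79 log units; beyond the scatter), concerns a different pair but runs in a related direction: a ring-bound amine of the same size replaced by an open chain carrying a hydroxyl made the number higher. The present change goes the other way, from an open chain to a six-membered ring carrying a hydroxymethyl group. Among the measured compounds shown here, without a value for compound 3 no step can be computed, so compound 4 is expected to fall between the two measured compounds, with an estimate of 6000 nM and a range from 2000 nM to 20000 nM.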

Compound 4, half-maximal inhibitory concentration: 8200 nM
Compound 4: the middle estimate sits 1.4-fold (0.14 log units) below what was measured; measured number inside the range.
By their numbers in this assay, from the lowest: compound 1; then compound 4; then compound 2.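

In this assay, closing the open chain into a ring gave a 2.3-fold lower number from compound 2 to compound 4 (0.37 log units; beyond the scatter), so at this carbonyl carbon 3-(hydroxymethyl)piperidin-1-yl reads better than (4-hydroxybutyl)amino, though both carry a hydroxyl. The ring alone does not restore the earlier number: with 3-(hydroxymethyl)piperidin-1-yl in place of 4-(ethoxycarbonyl)piperidin-1-yl there is a 2.6-fold higher number from compound 1 to compound 4 (0.42 log units; beyond the scatter), so two ring-bound amides at this place still differ beyond the scatter. The step from compound 3 to compound 4 cannot be read, as compound 3 has no value.

No measurement shown accounts for either step. Still open, on these data alone, is whether the gap between compound 1 and compound 4 follows from the ester or from where the ring carries its substituent, and how a carboxylic acid on the ring would read.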